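Cycloheptyl in Place of 4-Methoxyphenyl: an Expected Read-out

The compounds below may be only part of what the source reports. "The series", "measured", "known", "first", "only" and "open" are said of these compounds alone.

Three compounds were measured in a functional assay on CHO cells with adenosine receptor A1 (Homo sapiens) as the target, read by cAMP accumulation and immunoassay, with a stated time of 6 min, tested at 0.01 uM; on this read-out lower numbers stand for a stronger effect and higher numbers for a weaker effect at the one concentration tested:
- compound 1, `Nc1scc(CN2CCN(c3cc(Cl)cc(Cl)c3)CC2)c1C(=O)c1ccc(Cl)cc1`, gives -1%
- compound 2, `COc1ccc(N2CCN(Cc3csc(N)c3C(=O)c3ccc(Cl)cc3)CC2)cc1`, gives -1.2%
- compound 3, `Nc1scc(CN2CCN(c3c(F)cccc3F)CC2)c1C(=O)c1cccc(C(F)(F)F)c1`, gives 2.1%

Compound 2 holds the lowest of the three numbers, but its nearest neighbour, compound 1, sits within the scatter of it, and so does compound 3, the furthest; nothing in these three numbers separates one compound from another.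

Compound 4, `Nc1scc(CN2CCN(C3CCCCCC3)CC2)c1C(=O)c1ccc(Cl)cc1`, has not yet been measured. It differs from compound 2 in one place: cycloheptyl in place of 4-methoxyphenyl on an amine nitrogen in a ring

Within the data shown here, only one measured step touches the same amine nitrogen in the ring: a number 0.2 percentage points lower from compound 1 to compound 2 (within the scatter). Among the measured compounds shown here, that step exchanged one six-membered aromatic ring for another, whereas the change to compound 4 brings in a seven-membered non-aromatic ring of carbon only, so no measured pair shows this kind of exchange. For the measured compounds named here, all that the data offer is that every compound so far gives a read-out close to zero in this assay and that the one step at this position stayed within the scatter.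

Compound 4 is therefore expected to give 0%, with a range from -9% to 10%. The expected step is a number 1.2 percentage points higher from compound 2 to compound 4 (within the scatter), that is, no change beyond the scatter.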

Compound 4, a percentage reported as activity, at one concentration (the size of the read-out at that concentration, not a potency): 2.9%
Estimate against measurement, compound 4: 2.9 percentage points below; low and high end bracket the measured number.
By their numbers in this assay, from the lowest: compounds 2, 1, 3 and 4 (each within the scatter of the next).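

In this assay the position on an amine nitrogen in a ring now shows a different kind of exchange, with cycloheptyl entering in place of an aromatic group: a number 4.1 percentage points higher from compound 2 to compound 4 (within the scatter) and a number 3.9 percentage points higher from compound 1 to compound 4 (within the scatter). Among these compounds, the one earlier step at this nitrogen had only replaced one six-membered aromatic ring with another, whereas these two steps replace such a ring with a seven-membered non-aromatic ring of carbon only and, against 4-methoxyphenyl, also remove the one hydrogen-bond acceptor, yet neither step goes beyond the scatter. At the one concentration tested, this read-out therefore does not distinguish an aromatic from a non-aromatic ring on this nitrogen in these compounds, and no supporting data bear on why that is so.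

The compounds shown leave open whether the same holds for a group of another kind on this nitrogen, such as a benzyl group, a short alkyl chain or a carboxylic acid. They also leave open whether cycloheptyl would give a read-out within the scatter when combined with the trifluoromethyl-bearing part of compound 3.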